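Aryl exchange in the series: solubility working notes

The source may report more compounds than this note shows. Statements on the series, on what has been measured and on what is new or still open speak of the compounds shown alone.

In a physicochemical assay for solubility, read by spectrophotometry, in phosphate buffer, with a stated time of 18 h, at pH 7.4 (a lower number here means a less soluble compound, a higher number a more soluble compound), compound 1 `Cc1cccc(-c2nc3c(c(C)nn3-c3ccccc3)c(-c3ccccc3O)c2C#N)c1` reads 42000 nM and compound 2 `Cc1nn(-c2ccccc2)c2nc(-c3ccc(C#N)cc3)c(C#N)c(-c3ccccc3O)c12` reads 1700 nM while compound 3 `Cc1nn(-c2ccccc2)c2nc(-c3ccc(S(C)(=O)=O)cc3)c(C#N)c(-c3ccccc3O)c12` reads 5000 nM as the second highest of the three numbers. Compound 4 `Cc1nn(-c2ccccc2)c2nc(-c3ccc4c(c3)OCCO4)c(C#N)c(-c3ccccc3O)c12` carries 2,3-dihydro-1,4-benzodioxin-6-yl in place of 4-(methylsulfonyl)phenyl on an aromatic carbon. Three measured steps at this carbon bear on it, one large (a 25-fold lower number from compound 1 to compound 2 (1.39 log units; beyond the scatter)) and two modest (an 8.4-fold lower number from compound 1 to compound 3 (0.92 log units; beyond the scatter) and a 2.9-fold higher number from compound 2 to compound 3 (0.47 log units; beyond the scatter)). Compound 3 (5000 nM) lies inside that span and the entering group matches none of the groups compared there, so in this assay no step beyond the scatter is expected, with a slight upward lean. The expected step is a 1.4-fold higher number from compound 3 to compound 4 (0.15 log units; within the scatter) and stays within the scatter. Compound 4 is estimated at 7000 nM with 1800 nM to 27000 nM as the expected range.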

Compound 4, solubility: 11000 nM
For compound 4 the middle estimate is 1.6-fold (0.20 log units) below the measured one; the range from low to high includes it.
By their numbers in this assay, from the lowest: compound 2; then compound 3; then compound 4; then compound 1.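

In this assay 2,3-dihydro-1,4-benzodioxin-6-yl on this aromatic carbon reads above both 4-(methylsulfonyl)phenyl (a 2.2-fold higher number from compound 3 to compound 4 (0.34 log units; beyond the scatter)) and 4-cyanophenyl (a 6.5-fold higher number from compound 2 to compound 4 (0.81 log units; beyond the scatter)), so the order at this carbon now extends beyond the earlier three groups. It still falls short of 3-methylphenyl (a 3.8-fold lower number from compound 1 to compound 4 (0.58 log units; beyond the scatter)), which keeps the highest number of the four. Nothing shown accounts for this order.

From the compounds shown here alone, how a phenyl group carrying an amine or a carboxylic acid would read at this carbon stays open. Also open, going by these compounds, is whether the same order would hold with a different group in place of the 2-hydroxyphenyl group.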